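A few compounds are considered here, and "the series" means these few. Any claim that something is new, unique, unknown or untested is made for them only; others in the source may bear on it.

Going by the values given here, compound 3 `Fc1ccc(NC(=S)Nc2cccc(C(F)(F)F)c2)cc1` stands highest of the three compounds measured so far in an ADME assay on BHK cells (Mesocricetus auratus) for cytotoxicity, read by MTT assay, with a stated time of 96 h (a higher number here means that more compound is tolerated, a lower number that less compound is tolerated), where compound 3 gives 26000 nM. Compound 1 `CCCC[C@H]1CC[C@H](c2ccc(NC(=S)Nc3cccc(C(F)(F)F)c3)cc2)CC1` gives 9500 nM in this assay, and compound 2 `N#Cc1ccc(NC(=S)Nc2cccc(C(F)(F)F)c2)cc1` gives 9500 nM. The step of a 2.7-fold higher number from compound 1 to compound 3 (0.44 log units; beyond the scatter) and the step of a 2.7-fold higher number from compound 2 to compound 3 (0.44 log units; beyond the scatter) are both modest, while no change at the digits printed from compound 1 to compound 2 (within the scatter).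

Compound 4 `Fc1ccccc1NC(=S)Nc1cccc(C(F)(F)F)c1` has the same atoms as compound 3, joined differently: 2-fluorophenyl in place of 4-fluorophenyl on an amide-type nitrogen. Among the compounds with values here, none of the measured steps moves a fluorine from one place on the aromatic ring to another; the two steps that end at compound 3 exchange the whole group on the aromatic carbon, and each was only modest. Without a direct precedent, the new arrangement is expected to leave the number close to where compound 3 sits. For compound 4 the expected step is a 1.3-fold lower number from compound 3 to compound 4 (0.11 log units; within the scatter), with no confident direction either way. Compound 4 is therefore estimated at 20000 nM in this assay, within a range from 8000 nM to 50000 nM.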

Compound 4, half-maximal cytotoxic concentration: 54000 nM
Estimate against measurement, compound 4: 2.7-fold (0.43 log units) below; measured number outside the range, above it.
By their numbers in this assay, from the lowest: compounds 1 and 2 (each within the scatter of the next); then compound 3; then compound 4.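

Placing 2-fluorophenyl in place of 4-fluorophenyl on an amide-type nitrogen gives a 2.1-fold higher number from compound 3 to compound 4 (0.32 log units; beyond the scatter) in this assay, so the number at this position depends on where the fluorine stands on the ring, and not only on which group is exchanged. This step is modest but beyond the scatter, and it comes with no change in the atoms, whereas a 2.7-fold higher number from compound 1 to compound 3 (0.44 log units; beyond the scatter) and a 2.7-fold higher number from compound 2 to compound 3 (0.44 log units; beyond the scatter) each exchange a whole group. Nothing shown here bears on what lies behind this shift.

The compounds shown leave open whether a chlorine, a methoxy group or an amine in place of the fluorine would follow the same course. They also leave open whether moving the nitrile of compound 2 in the same way would raise the number, and what a second fluorine on that ring would do.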